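A few compounds are considered here, and "the series" means these few. Any claim that something is new, unique, unknown or untested is made for them only; others in the source may bear on it.

In a physicochemical assay for solubility, at pH 7.4 (on this read-out lower numbers stand for lower solubility and higher numbers for higher solubility), compound 2 `C[C@@H]1[C@@H](N(C)C)CN1c1c(F)cc2c(=O)c(C(=O)O)cn(C3CC3)c2c1F` reads 97.1 ug/mL and so holds the higher of the two numbers in hand, ahead of compound 1 `CNC1(C)CN(c2c(F)cc3c(=O)c(C(=O)O)cn(C4CC4)c3c2F)C1` at 0.5 ug/mL on the same scale. Going by the values given here, the one measured step of a 190-fold higher number from compound 1 to compound 2 (2.29 log units; beyond the scatter) is large and beyond the scatter, and it lies at the same place on an aromatic carbon where compound 3 `C[C@H]1[C@H](N)CN1c1c(F)cc2c(=O)c(C(=O)O)cn(C3CC3)c2c1F` also differs. The new change reads a group of 6 heavy atoms (4 carbon, 2 nitrogen; one four-membered non-aromatic ring with 1 hetero atom) in place of a group of 8 heavy atoms (6 carbon, 2 nitrogen; one four-membered non-aromatic ring with 1 hetero atom), on an aromatic carbon and leaves the shared core as it was. The step of a 190-fold higher number from compound 1 to compound 2 (2.29 log units; beyond the scatter) shows that the number can shift far at this place, yet on its own it gives no direction for the new group. A moderate fall, well short of that size, is expected, with wide margins. The estimated move is a 3.2-fold lower number from compound 2 to compound 3 (0.51 log units; beyond the scatter) on this reading. For compound 3 the estimated value is 30 ug/mL with an expected range from 3 ug/mL to 300 ug/mL on this read-out.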

Compound 3, solubility: 23.2 ug/mL
The estimate for compound 3 lay 1.3-fold (0.11 log units) above the measured number, within the range that was stated.
By their numbers in this assay, from the lowest: compound 1; then compound 3; then compound 2.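

The change from the group of 8 heavy atoms to the group of 6 heavy atoms gives a 4.2-fold lower number from compound 2 to compound 3 (0.62 log units; beyond the scatter) in this assay, a modest step that shows this aromatic carbon also responds to a smaller change than the first one seen there. Compound 3 still stands far from compound 1, with a 46-fold higher number from compound 1 to compound 3 (1.67 log units; beyond the scatter), so the large gap from compound 1 is not confined to the group in compound 2. No measurement is at hand that gives a reason for either step.

Each step swaps a whole group, so the share of any single part of it, including the hydrogen-bond donor that enters with compound 3, stays unresolved. Going by these compounds, how a piperazine ring would read on this aromatic carbon, ortho to two fluoro groups, also remains open.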